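Neopentyl in place of 4-fluoro-3-methoxyphenyl: compound 4

The compounds below may be only part of what the source reports. "The series", "measured", "known", "first", "only" and "open" are said of these compounds alone.

Measured so far in an ADME assay on 2209-23 cells (Homo sapiens) for cytotoxicity, read by WST assay (a lower number here means that less compound is tolerated, a higher number that more compound is tolerated), each value a limit:
- compound 1 `CS(=O)(=O)Nc1ccc2c(c1)S(=O)(=O)C=C(c1c(O)c3cccc(F)c3n(Cc3ccc(F)cc3)c1=O)N2`: > 50000 nM
- compound 2 `CS(=O)(=O)Nc1ccc2c(c1)S(=O)(=O)C=C(c1c(O)c3cc(F)ccc3n(Cc3ccc(F)c(Cl)c3)c1=O)N2`: > 50000 nM
- compound 3 `COc1cc(Cn2c(=O)c(C3=CS(=O)(=O)c4cc(NS(C)(=O)=O)ccc4N3)c(O)c3cc(F)ccc32)ccc1F`: > 50000 nM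

Compound 3 stands at > 50000 nM, which is a limit and not a number. The same holds for the other two compounds, so the series offers no measured value to rank them by. The next compound, compound 4 `CC(C)(C)CCn1c(=O)c(C2=CS(=O)(=O)c3cc(NS(C)(=O)=O)ccc3N2)c(O)c2cc(F)ccc21`, carries neopentyl in place of 4-fluoro-3-methoxyphenyl on a saturated chain carbon bound to an aromatic nitrogen.

For the measured compounds named here, only one measured step bears on this series, a step that the two limits leave unreadable from compound 2 to compound 3. It concerns methoxy in place of chloro on an aromatic carbon, a different change at a different level of substitution, and it gives no size to carry over. The remaining evidence is the limit of > 50000 nM in this assay, at which 3 of the 3 values shown sit. Going by the values given here, on that basis, no step of readable size and no particular direction is expected in this assay, and another limit is the most likely report. The expected step, a number no higher from compound 3 to compound 4 (the limit leaves the size open), is therefore only a rough estimate. Compound 4 is expected at about 50000 nM, with an estimated range from 25000 nM to 100000 nM.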

Compound 4, half-maximal cytotoxic concentration: > 50000 nM
Compound 4: a limit, no number (the forecaster's own chance of this, stated with the estimate: 80%); the middle value sits exactly at the limit.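

Compound 4 gives > 50000 nM, a limit and not a number, so its steps from compound 2 and compound 3 cannot be read. The compounds shown leave open the actual half-maximal cytotoxic concentration of each compound, and so whether the changes in the substituent on the ring nitrogen shift it at all: the limit of > 50000 nM in this assay, at which 4 of the 4 values shown sit.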